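The source may report more compounds than this note shows. Statements on the series, on what has been measured and on what is new or still open speak of the compounds shown alone.

Measured so far:
compound 1, `COc1cc2cc(N)c(=O)oc2cc1OCCCOc1no[n+]([O-])c1S(=O)(=O)c1ccccc1`, 2020 nM
compound 2, `COc1cc2cc(C(=O)NCCCc3ccc(F)cc3)c(=O)oc2cc1OCCCOc1no[n+]([O-])c1S(=O)(=O)c1ccccc1`, 600 nM

Of the compounds shown here, two sharing one core have been tested in a functional assay on MCF7 cells (Homo sapiens) for inhibition, read by MTT assay, with a stated time of 48 h; a lower number here means a stronger inhibitor, a higher number a weaker inhibitor. Compound 1 gives 2020 nM there, while compound 2 gives 600 nM, the lower of the two numbers, a gap that lies beyond the usual scatter. Going by the values given here, no single-point step between the two measured compounds is available, as they differ in more than one place.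

Compound 3, `COc1ccc(CNC(=O)c2cc3cc(OC)c(OCCCOc4no[n+]([O-])c4S(=O)(=O)c4ccccc4)cc3oc2=O)cc1`, has not yet been measured. It differs from compound 2 by 4-methoxyphenyl in place of 2-(4-fluorophenyl)ethyl on a saturated chain carbon bound to an amide-type nitrogen. The amide linkage and the rest of the molecule are unchanged. With only compound 1 and compound 2 as reference, nothing in the data speaks to how the aromatic substituent or the chain length on this saturated carbon matters. The expectation is therefore a modest step, if any, in this assay, with the number most likely staying near that of compound 2 and a small shift toward weaker inhibition considered somewhat more probable than the reverse. The expected step is a 1.3-fold higher number from compound 2 to compound 3 (0.12 log units; within the scatter). Compound 3 is estimated at 800 nM, with a range from 350 nM to 1800 nM.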

Compound 3, half-maximal inhibitory concentration: 560 nM
The estimate for compound 3 lay 1.4-fold (0.15 log units) above the measured number; measured number inside the range.
By their numbers in this assay, from the lowest: compounds 3 and 2 (each within the scatter of the next); then compound 1.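

In this assay, 4-methoxyphenyl in place of 2-(4-fluorophenyl)ethyl on a saturated chain carbon bound to an amide-type nitrogen gives a 1.1-fold lower number from compound 2 to compound 3 (0.03 log units; within the scatter), so this place tolerates a change of both the chain and the ring substituent, with 4-methoxybenzyl and 3-(4-fluorophenyl)propyl reading alike here. Going by these compounds alone, the first single-place step at the aromatic carbon of the shared core comes with (4-methoxybenzyl)carbamoyl in place of amino, which gives a 3.6-fold lower number from compound 1 to compound 3 (0.56 log units; beyond the scatter) and ties the gain over the amino compound to a single change. Nothing measured on these compounds explains either step.

Going by these compounds, whether the amide nitrogen needs an aromatic ring at all remains open, since a plain methyl or cyclohexyl group there, or an unsubstituted benzyl group, could read either like compound 3 or like something quite different. On these data alone, it is also open how a carboxylic acid or an ester on that aromatic carbon would compare with the carbamoyl of compound 3 and the amino of compound 1.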